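Swapping the Amide Substituent on a Thiophene Dihydropyrimidinone

The source may hold more compounds than are shown below. What is called first, only, known or untested is meant among the compounds shown, and "the series" means these compounds.

Measured compounds:
- Compound 1, `CCCOC(=O)C1=C(C)NC(=O)NC1c1ccsc1`: 44%
- Compound 2, `CC(=O)C1=C(C)NC(=O)NC1c1ccsc1`: 9%
- Compound 3, `CC1=C(C(=O)NC(C)C)C(c2ccsc2)NC(=O)N1`: 8%

The three compounds share one core and differ only in the group attached to a carbonyl carbon. In an assay on membranes from CHO cells for displacement of a labelled ligand from adenosine receptor A1 (Homo sapiens), read by scintillation counting, with a stated time of 60 min, tested at 1 uM (a lower number here means less inhibition, a higher number more inhibition at the concentration tested (going by the name of the read-out)), compound 1 gives 44%. Compound 3 gives the lowest of the three numbers in this assay; its nearest neighbour is compound 2, whose value lies within the scatter of it, while compound 1 is the furthest from it, beyond the scatter.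

The unmeasured compound 4, `CCN(CC)C(=O)C1=C(C)NC(=O)NC1c1ccsc1`, differs from compound 3 in one place: diethylamino in place of isopropylamino on a carbonyl carbon.

Going by the values given here, two measured steps bear on this. The step of a number 36 percentage points lower from compound 1 to compound 3 (beyond the scatter) was large, but it replaced an ester-type group with an amino group. The step of a number 1 percentage points lower from compound 2 to compound 3 (within the scatter) stayed within the scatter. Among the compounds with values here, neither step exchanges one amino group for another, so there is no measured step that matches the change to compound 4 directly. The closest analogy is the small step from compound 2 to compound 3, so a step of no size beyond the scatter is expected in this assay.

For compound 4 the expected value in this assay is 10%, with a range from 0% to 28%, which means an expected step of a number 2 percentage points higher from compound 3 to compound 4 (within the scatter).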

Compound 4, a percentage reported as inhibition, at one concentration (the size of the read-out at that concentration, not a potency): 11%
Compound 4: middle estimate off by 1 percentage points, on the low side, and the stated range covers the measured number.
By their numbers in this assay, from the lowest: compounds 3, 2 and 4 (each within the scatter of the next); then compound 1.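

In this assay, going by these compounds alone, the first exchange of one amino group for another on this carbonyl carbon gives a number 3 percentage points higher from compound 3 to compound 4 (within the scatter), so losing the amide hydrogen and moving to diethylamino leaves the reading unchanged within the usual variation. Diethylamino also sits close to the small methyl group, with a number 2 percentage points higher from compound 2 to compound 4 (within the scatter), whereas against propoxy there is a number 33 percentage points lower from compound 1 to compound 4 (beyond the scatter), so among these four compounds propoxy alone stands apart, and isopropylamino, diethylamino and methyl cannot be told apart at this single test concentration. Nothing available explains why the propoxy compound behaves differently.

As far as these compounds go, whether that higher reading belongs to esters in general or to the propoxy group in particular stays open, and shorter or longer ester chains such as ethoxy or butoxy on the same carbonyl carbon would speak to that. From the compounds shown here alone, it is also open whether every amino group stays as low as these two, since a larger one such as benzylamino or the plain unsubstituted amino group could behave differently.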